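A few compounds are considered here, and "the series" means these few. Any claim that something is new, unique, unknown or untested is made for them only; others in the source may bear on it.

Measured so far in a functional assay on HT-29 cells (Homo sapiens) for cytotoxicity, read by sulforhodamine B assay; a higher number here means a weaker inhibitor of growth, a lower number a stronger inhibitor of growth:

compound 2, `O=c1oc2ccccc2cc1-c1cn2nc(-c3c([O-])[o+]nn3-c3ccccc3)sc2n1`: 6.3 ug/mL
compound 1, `O=c1oc2ccc(Cl)cc2cc1-c1cn2nc(-c3c([O-])[o+]nn3-c3ccc(Cl)cc3)sc2n1`: 8 ug/mL

Compound 2 has the lower of the two numbers, but compound 1 lies so close to it that the two stand within the usual scatter of this assay, and no order between them can be read. Within the data shown here, the two measured compounds differ at two places at once, so no single step between measured compounds is available to guide a prediction.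

Compound 3, `O=c1oc2ccccc2cc1-c1cn2nc(-c3c([O-])[o+]nn3-c3ccc(Cl)cc3)sc2n1`, differs from compound 2 in one place: chloro in place of hydrogen on an aromatic carbon. Compound 1 carries this same chloro together with a second chloro on the other ring of the shared core, and its value of 8 ug/mL does not separate from that of compound 2 beyond the scatter. Among the measured compounds shown here, on that basis the single chloro in compound 3 is expected to leave the number essentially where it is, with no step beyond the scatter in either direction.

For compound 3 the expected step from compound 2 is a 1.1-fold higher number from compound 2 to compound 3 (0.05 log units; within the scatter). Compound 3 is therefore estimated at 7 ug/mL, within a range from 3.5 ug/mL to 14 ug/mL.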

Compound 3, concentration for 50% growth inhibition: 4 ug/mL
Estimate against measurement, compound 3: 1.8-fold (0.24 log units) above, within the range that was stated.
By their numbers in this assay, from the lowest: compounds 3, 2 and 1 (each within the scatter of the next).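

Among these compounds, with compound 3 in this assay, phenyl to 4-chlorophenyl can be read alone for the first time, and the step (a 1.6-fold lower number from compound 2 to compound 3 (0.20 log units; within the scatter)) shows no separation between chloro and hydrogen at this place, on an aromatic carbon para to a large group. The chloro on the other ring of the shared core can now also be read alone, and its removal (a 2.0-fold lower number from compound 1 to compound 3 (0.30 log units; within the scatter)) likewise stays inside the scatter, whereas the earlier pair carried both changes at once and could not tell them apart. Nothing measured in this account explains either step, so the result stands as a plain observation on these compounds.

The compounds shown carry only chloro or hydrogen at these two places, so it remains open whether a methoxy group, an amine or a carboxylic acid at the same carbon of the phenyl ring would give a step beyond the scatter. As far as these compounds go, it also remains open whether chloro on another carbon of that ring would leave the number as undisturbed as it does here.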